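Two chain lengthenings on an amide in the same series

The source may hold more compounds than are shown below. What is called first, only, known or untested is meant among the compounds shown, and "the series" means these compounds.

The measured compounds, with their values in an assay on isolated protein for inhibition of Nitric oxide synthase, inducible (Homo sapiens), with a stated time of 30 min, tested at 1 mM; on this read-out higher numbers stand for more inhibition at the one concentration tested (going by the name of the read-out) and lower numbers for less inhibition:
compound 1 `COc1ccc(N)c(C2=NN(C(C)=O)CC2)c1` gives 20.4%
compound 2 `CCC(=O)N1CCC(c2cc(OC)ccc2N)=N1` gives 20.4%
compound 3 `CCC(=O)N1CCC(c2ccccc2N)=N1` gives 6.88%

Compound 4 `CCCC(=O)N1CCC(c2ccccc2N)=N1` has not been measured. It arises from compound 3 by the change (methyl in place of hydrogen on a saturated chain carbon, two bonds along the chain from a carbonyl carbon). The same kind of change has already been made once, from compound 1 to compound 2, as methyl in place of hydrogen on a saturated chain carbon bound to a carbonyl carbon, though there the place differs: the new carbon sits on a saturated chain carbon bound to a carbonyl carbon, whereas in compound 4 it sits two bonds along the chain from the carbonyl carbon. That earlier step gave no change at the digits printed from compound 1 to compound 2 (within the scatter). The difference between the core of compound 1 and the core of compound 3 is not broken down here; within the series, a number 13.5 percentage points lower from compound 2 to compound 3 (beyond the scatter) marks the move from the methoxy-bearing core to the unsubstituted one.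

On the strength of the earlier step, compound 4 is expected to show about a number 0.1 percentage points higher from compound 3 to compound 4 (within the scatter) against compound 3, and its value in this assay is estimated at 7%, between 0% and 18%.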

Compound 4, a percentage reported as inhibition, at one concentration (the size of the read-out at that concentration, not a potency): 0.35%
For compound 4 the middle estimate is 6.7 percentage points above the measured one, within the range that was stated.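

In this assay the added methyl gave a number 6.5 percentage points lower from compound 3 to compound 4 (within the scatter), so this step, like the earlier one, cannot be told from no change. Set side by side, the two chain lengthenings on the amide agree across the two cores: the same change on two cores in this assay, no change at the digits printed (within the scatter) from compound 1 to compound 2 and a number 6.5 percentage points lower (within the scatter) from compound 3 to compound 4, 6.5 percentage points apart, within the scatter of two such steps This supports carrying such a lengthening from one core to the other without a detectable shift in this read-out, but it does not show that the change is without effect in general: the new carbon sits in a different place in the two steps, only two cores are covered, and a percentage at one concentration is not a potency.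

The compounds shown leave open how a longer chain than propylcarbonyl, a branched chain or a chain carrying an amine or a carboxylic acid would read on either core. They also leave open whether propylcarbonyl on the core of compound 2 would stay level with that compound.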